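The source may hold more compounds than are shown below. What is called first, only, known or untested is meant among the compounds shown, and "the series" means these compounds.

In an ADME assay on a cell-free system (plasma, Mus musculus, strain CD-1) for metabolic stability, tested at 10 uM (on this read-out lower numbers stand for a shorter-lived compound and higher numbers for a longer-lived compound), compound 1 (`COc1ccccc1C1=NN(c2ccccn2)C(=O)C1`) gives 0.182 h and compound 2 (`COc1ccc(C2=NN(c3ccccn3)C(=O)C2)cc1`) gives 0.2 h and the two values lie within the scatter of each other, so compound 2 stands level with compound 1 and neither can be called the longer-lived.

Compound 3 (`COc1ccc(C2=NN(c3ccccn3)C(=O)C2)cc1OC`) is compound 2 with methoxy in place of hydrogen on an aromatic carbon, ortho to a methoxy group and meta to a large group (methoxy in place of hydrogen on an aromatic carbon). Within the data shown here, no measured pair shows this change, so the data give no direct guide to its size. The expectation rests only on the two measured compounds, which sit level in this assay with compound 1 at 0.182 h and compound 2 at 0.2 h on the same shared core. No step beyond the scatter is expected in this assay and no direction is favoured. The estimate is no change at the digits printed from compound 2 to compound 3 (within the scatter) as an expected step within the scatter. For compound 3 the expected half-life is 0.2 h with an estimated range from 0.1 h to 0.4 h as the working figure.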

Compound 3, half-life in the Mus musculus assay: 0.5 h
The estimate for compound 3 lay 2.5-fold (0.40 log units) below the measured number, and the stated range ends below it.
By their numbers in the Mus musculus assay, from the lowest: compounds 1 and 2 (each within the scatter of the next); then compound 3.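

Among these compounds, in the Mus musculus assay, methoxy in place of hydrogen on the aromatic carbon ortho to a methoxy group and meta to a large group gives a 2.5-fold higher number from compound 2 to compound 3 (0.40 log units; beyond the scatter), the first step read as beyond the scatter. This position is therefore not silent in this read-out: the change moves the number toward the longer-lived end, which the two earlier compounds, standing level with each other, could not show. In a physicochemical assay for lipophilicity, read by LC-MS, in phosphate buffer, measured as octanol-water partition, with a stated time of 2 h, at pH 7.4 (a lower number here means a more polar compound, a higher number a more lipophilic compound), compound 2 gives 2.82 and compound 3 gives 2.19 so the same change goes with a more polar compound, and in this single pair the longer half-life does not come with higher lipophilicity: the measured distribution coefficient of compound 2, 2.82, and of compound 3, 2.19, a number 0.63 log units lower (beyond the scatter)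

A single pair cannot show whether the step belongs to methoxy itself or to any substituent at this aromatic carbon, and a fluorine, a hydroxyl or an amine at the same place would test that in the Mus musculus assay. From the compounds shown here alone, whether the half-life and the distribution coefficient move together across the series also stays open, as one pair cannot link the two read-outs.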